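The source may report more compounds than this note shows. Statements on the series, on what has been measured and on what is new or still open speak of the compounds shown alone.

Going by the values given here, compound 1 `COc1ccc(-c2cc(/C=C/C(=O)c3ccc(N)cc3)[nH]n2)cc1` is one of two compounds measured in a functional assay on NCI-H460 cells (Homo sapiens) for cytotoxicity, read by sulforhodamine B assay, with a stated time of 48 h, tested at 10 uM; on this read-out higher numbers stand for a weaker effect at the one concentration tested and lower numbers for a stronger effect. In this assay compound 1 gives -40%, the lower of the two numbers shown. Compound 2 `COc1cc(-c2cc(/C=C/C(=O)c3ccc(F)c(F)c3)[nH]n2)cc(OC)c1OC` gives -9% in this assay, a weaker effect than compound 1 by a gap that lies beyond the scatter; compound 2 differs from compound 1 at more than one place, so no single change can be read from that gap. Compound 3 `COc1ccc(-c2cc(/C=C/C(=O)c3ccc(N)cc3)[nH]n2)cc1OC` has not yet been measured. It differs from compound 1 in one place: methoxy in place of hydrogen on an aromatic carbon. Among the compounds with values here, no measured pair shows this change on its own, and the numbers for compound 2 cannot separate the added methoxy groups from the other differences. A small step in this assay is expected, slightly toward a weaker effect, possibly none beyond the scatter. Compound 3 is therefore estimated to give -30% in this assay, with a range from -60% to 5%, which means an expected step of a number 10 percentage points higher from compound 1 to compound 3 (within the scatter).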

Compound 3, a percentage reported as activity, at one concentration (the size of the read-out at that concentration, not a potency): -49%
The estimate for compound 3 lay 19 percentage points above the measured number; the measured number falls inside the stated range.
By their numbers in this assay, from the lowest: compounds 3 and 1 (each within the scatter of the next); then compound 2.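

Going by these compounds alone, compound 3 gives the first direct reading of methoxy in place of hydrogen on an aromatic carbon: in this assay the change gives a number 9 percentage points lower from compound 1 to compound 3 (within the scatter). At this place, ortho to a methoxy group and meta to a large group, the added methoxy leaves compound 1 and compound 3 indistinguishable at the one concentration tested, so the strong read-out of compound 1 survives this addition. Nothing available here offers an explanation for this result.

As far as these compounds go, whether a hydroxy group, a fluorine atom or a longer chain such as ethoxy at this same place would behave like methoxy remains open. Compound 2 differs from compound 1 and compound 3 at more than one place, so its gaps to them cannot be read as steps, and the part played by the amine on the other aromatic ring stays unresolved.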